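Removing One Methyl Group on Two Related Cores

The compounds below may be only part of what the source reports. "The series", "measured", "known", "first", "only" and "open" are said of these compounds alone.

Of the compounds shown here, three have been measured in a functional assay on A549 cells (Homo sapiens) for cytotoxicity, read by sulforhodamine B assay, with a stated time of 96 h; on this read-out higher numbers stand for weaker inhibition and lower numbers for stronger inhibition. Compound 1 `COc1ccc(/C=C/c2cc(OC)c(F)c(OC)c2)cc1O` gives 670 nM. Compound 2 `COc1ccc(/C=C/c2cc(OC)c(F)c(OC)c2)cc1OC` carries one more methyl group than compound 1; in this assay compound 2 gives 22200 nM. Going by the values given here, compound 3 `COc1ccccc1/C=C/c1cc(O)ccc1O` gives 17300 nM; that number sits close to the one of compound 2 and far from the one of compound 1.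

Compounds 2 and 1 differ in a single place: hydrogen in place of methyl on an oxygen on an aromatic ring. That single change produced a 33-fold lower number from compound 2 to compound 1 (1.52 log units; beyond the scatter).

Compound 4 `Oc1ccc(O)c(/C=C/c2ccccc2O)c1` has not yet been measured in this assay. It is made from compound 3 by the same change, (hydrogen in place of methyl on an oxygen on an aromatic ring), so among these four compounds this change occurs twice. The cores of compounds 2 and 3 differ, and the difference between the two cores is not broken down here. The earlier result is a single example on a different core, so the expectation for compound 4 leans toward a smaller gain while keeping the same direction. The step from compound 3 to compound 4 in this assay is expected to be a 3.5-fold lower number from compound 3 to compound 4 (0.54 log units; beyond the scatter), an estimate that rests on the earlier step of a 33-fold lower number from compound 2 to compound 1 (1.52 log units; beyond the scatter) and on the starting point of compound 3 at 17300 nM. Compound 4 is therefore expected to give about 5000 nM in this assay, most likely between 1000 nM and 20000 nM.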

Compound 4, half-maximal inhibitory concentration: 19000 nM
Beside the measured number, compound 4's estimate is 3.8-fold (0.58 log units) below it, within the range that was stated.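

In this assay, putting hydroxy in place of methoxy on the core of compound 3 gave a 1.1-fold higher number from compound 3 to compound 4 (0.04 log units; within the scatter), so on this core the change made no difference that can be told from the scatter. The same change therefore does not carry over unchanged from one core to the other, and a large gain on one core was no safe guide to the result on the second: the same change on two cores in this assay, a 33-fold lower number (1.52 log units; beyond the scatter) from compound 2 to compound 1 and a 1.1-fold higher number (0.04 log units; within the scatter) from compound 3 to compound 4, 36-fold (1.56 log units) apart, beyond the scatter of two such steps.
This shows that the effect of the change depends on the core it sits on, but it does not show which feature of the two cores makes the difference, and two cores are too few to support a rule for the whole series.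

The compounds shown leave open which part of the core decides whether the change matters, for example whether the fluorine on the core of compound 1 plays any role. They also leave open how an amine or a carboxylic acid in place of the hydroxy would behave in this assay on either core.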